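Series notes: aryl exchange on compound 2

This account rests on a few compounds, and the source may have more. Where it says the series, first, only, none or still open, it means among the compounds named here.

Measured compounds:
compound 1 `COc1ccc(C2=NN(C3=NC(=O)/C(=C4\C(=O)Nc5ccc(Cl)cc54)S3)C(c3ccc(Cl)cc3)C2)cc1`, 450 nM
compound 2 `COc1ccc(-c2cc(-c3ccc(Cl)cc3)n(C3C(=O)Nc4ccc(Br)cc43)n2)cc1`, 36300 nM
compound 3 `COc1ccc(-c2cc(-c3ccc(Cl)cc3)n(C3C(=O)Nc4ccc(Cl)cc43)n2)cc1`, 28600 nM

In a functional assay on cells (Cancer cell lines, Homo sapiens) for cytotoxicity, read by sulforhodamine B assay, with a stated time of 48 h (on this read-out lower numbers stand for stronger inhibition of growth and higher numbers for weaker inhibition of growth), compound 1 gives 450 nM, compound 2 gives 36300 nM and compound 3 gives 28600 nM. Compound 2 stands highest of the three numbers; its nearest neighbour is compound 3, which lies within the scatter, while compound 1 lies far lower, beyond the scatter.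

Compound 4 `O=C1Nc2ccc(Br)cc2C1n1nc(-c2ccc3ccccc3c2)cc1-c1ccc(Cl)cc1` is not yet measured. It differs from compound 2 by naphthalen-2-yl in place of 4-methoxyphenyl on an aromatic carbon. For the measured compounds named here, the only measured single step is a 1.3-fold lower number from compound 2 to compound 3 (0.10 log units; within the scatter), a halogen exchange that does not test the aryl group; no measured pair bears directly on this change. Compound 4 is therefore expected to show a 1.2-fold lower number from compound 2 to compound 4 (0.08 log units; within the scatter) in this assay, with wide uncertainty. The estimate for compound 4 in this assay is 30000 nM, expected between 8000 nM and 100000 nM.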

Compound 4, concentration for total growth inhibition: 15000 nM
Beside the measured number, compound 4's estimate is 2.0-fold (0.30 log units) above it, within the range that was stated.
By their numbers in this assay, from the lowest: compound 1; then compounds 4, 3 and 2 (each within the scatter of the next, the first and the last beyond it).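

In this assay, the position on the five-membered aromatic ring two ring bonds from the ring atom that bears a 4-chlorophenyl group now has a direct reading: naphthalen-2-yl in place of 4-methoxyphenyl gives a 2.4-fold lower number from compound 2 to compound 4 (0.38 log units; beyond the scatter), a modest change. The halogen exchange, a 1.3-fold lower number from compound 2 to compound 3 (0.10 log units; within the scatter), left this aryl group untested and stayed within the scatter, whereas this step lies beyond it. No available evidence explains the change.

Going by these compounds, it remains open whether the same exchange carries over to compound 3 with its chloro group. A plain phenyl, or an amine or carboxylic acid on the aryl group, would show how far this position responds.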